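Isopropyl in Place of Hydrogen on the Phenyl of Compound 2

The source may hold more compounds than are shown below. What is called first, only, known or untested is meant among the compounds shown, and "the series" means these compounds.

Going by the values given here, compound 2 `CN(C)C(=O)c1cccnc1NCCCN1CCN(c2ccccc2)CC1` stands lowest of the three numbers measured so far in a functional assay on aorta for antagonist activity at Alpha-1D adrenergic receptor (Rattus norvegicus) (a lower number here means tighter binding, a higher number weaker binding), where compound 2 gives 15.9 nM. Compound 1 `COc1ccccc1N1CCN(CCCNc2cncnc2C(=O)N(C)C)CC1` gives 50.1 nM in this assay, and compound 3 `CN(C)C(=O)c1cccnc1NCCCN1CCN(c2ccccc2OC(F)(F)F)CC1` gives 100 nM. Compound 1 and compound 2 differ in more than one place, so their two values can only be set side by side. Compound 4 `CC(C)c1ccccc1N1CCN(CCCNc2ncccc2C(=O)N(C)C)CC1` has not yet been measured; it differs from compound 2 by isopropyl in place of hydrogen on an aromatic carbon. Among the compounds with values here, one measured step bears on this change: a 6.3-fold higher number from compound 2 to compound 3 (0.80 log units; beyond the scatter), a group entering in place of hydrogen on the same aromatic carbon. Isopropyl is a different group from trifluoromethoxy, but the only evidence in hand points toward a higher number, so compound 4 is expected to come out weaker than compound 2, though by less than that step. The estimate for compound 4 is 40 nM, with a range from 15 nM to 120 nM. The step this estimate implies is a 2.5-fold higher number from compound 2 to compound 4 (0.40 log units; beyond the scatter).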

Compound 4, dissociation constant: 63.1 nM
For compound 4 the middle estimate is 1.6-fold (0.20 log units) below the measured one; measured number inside the range.
By their numbers in this assay, from the lowest: compound 2; then compounds 1, 4 and 3 (each within the scatter of the next).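

At the place ortho to a large group on the phenyl of compound 2, a second group now gives a higher number in this assay: the change to isopropyl gives a 4.0-fold higher number from compound 2 to compound 4 (0.60 log units; beyond the scatter) and so the rise seen with trifluoromethoxy is no longer a single case. The two groups cannot be told apart in this assay since exchanging one for the other gives a 1.6-fold lower number from compound 3 to compound 4 (0.20 log units; within the scatter) and this holds even though they are different groups. Nothing at hand accounts for the higher number with either group.

Still open, going by these compounds, is whether a methyl group, a chlorine atom, an amine or a carboxylic acid at this place would also give a higher number than compound 2. On these data alone, it is also open whether isopropyl would have the same effect on the core of compound 1.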